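Growth inhibition of a pyridone series: from compound 3 to compound 4

A few compounds are considered here, and "the series" means these few. Any claim that something is new, unique, unknown or untested is made for them only; others in the source may bear on it.

Measured compounds:
- compound 1, `CS(=O)(=O)c1ccc(-c2cnc3[nH]cc(-c4nnc(-c5ccccc5)o4)c(=O)c3c2)cc1`: 27.2%
- compound 2, `O=c1c(-c2nnc(-c3ccc(F)cc3)o2)c[nH]c2ncc(-c3cccnc3)cc12`: 20.1%
- compound 3, `CS(=O)(=O)c1ccc(-c2cnc3[nH]cc(-c4nnc(-c5ccccn5)o4)c(=O)c3c2)cc1`: 34.3%

Of the compounds shown here, three share one core and have been tested in a functional assay on HCT-116 cells (Homo sapiens) for positive allosteric modulation, read by MTT assay, with stated times of 24 h and 48 h, tested at 2.5 uM; a lower number here means less inhibition of growth, a higher number more inhibition of growth at the concentration tested. Compound 3 gives the highest of the three numbers, but its nearest neighbour, compound 1, lies within the scatter of it, so no order between those two can be claimed; only compound 2 sits beyond the scatter below compound 3. Among the compounds with values here, the one single-point step measured so far, a number 7.1 percentage points higher from compound 1 to compound 3 (within the scatter), exchanged phenyl for pyridin-2-yl and stayed within the scatter.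

Compound 4, `Cc1ccc(-c2nnc(-c3c[nH]c4ncc(-c5ccc(S(C)(=O)=O)cc5)cc4c3=O)o2)cc1`, arises from compound 3 by 4-methylphenyl in place of pyridin-2-yl on an aromatic carbon. Within the data shown here, the step from phenyl to pyridin-2-yl bears on it, as it concerns the same position, and it was small; the added methyl has no measured counterpart here. Because a number 7.1 percentage points higher from compound 1 to compound 3 (within the scatter) was within the scatter, compound 4 is expected to show a number 6.3 percentage points lower from compound 3 to compound 4 (within the scatter), a step of no certain direction. The estimate for compound 4 is 28%, between 15% and 42%.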

Compound 4, percent growth inhibition at one concentration: 54.8%
Compound 4: the middle estimate sits 26.8 percentage points below what was measured; the measured number lies above the stated range.
By their numbers in this assay, from the lowest: compounds 2, 1 and 3 (each within the scatter of the next, the first and the last beyond it); then compound 4.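

On an aromatic carbon of the five-membered aromatic ring with 2 nitrogen and 1 oxygen, 4-methylphenyl in place of pyridin-2-yl gave a number 20.5 percentage points higher from compound 3 to compound 4 (beyond the scatter) in this assay, whereas the earlier exchange of phenyl for pyridin-2-yl at this position had stayed within the scatter. Methyl in place of hydrogen on an aromatic carbon of the phenyl group gave a number 27.6 percentage points higher from compound 1 to compound 4 (beyond the scatter), so a single added methyl on this group was enough to move the number beyond the scatter. Nothing at hand explains this rise.

The compounds shown leave open whether the rise is specific to methyl or would also appear with an ethyl, a methoxy group or a chlorine atom in its place. They also leave open what an amine or a carboxylic acid on this phenyl group would do.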